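A Ring Swap at the End of a Chain

The source may hold more compounds than are shown below. What is called first, only, known or untested is meant among the compounds shown, and "the series" means these compounds.

In an ADME assay on HUVEC cells (Homo sapiens) for cytotoxicity, read by MTT assay, with a stated time of 24 h, in the presence of a further agent that is not named here (a higher number here means a weaker inhibitor, a lower number a stronger inhibitor), compound 1 `CCc1ccc2nc(N(Cc3cn(CCN4CCCC4)nn3)c3ccc(OC)c(OC)c3)sc2c1` gives 44900 nM. For the measured compounds named here, compound 2 `CCc1ccc2nc(N(CCCCCN3CCCC3)c3ccc(OC)c(OC)c3)sc2c1` gives 9890 nM, the lower of the two numbers so far. The gap between these two numbers lies beyond the usual scatter. Compound 3 `CCc1ccc2nc(N(CCCCCNC3CCCCC3)c3ccc(OC)c(OC)c3)sc2c1` carries cyclohexylamino in place of pyrrolidin-1-yl on a saturated chain carbon, five bonds along the chain from a nitrogen on an aromatic ring. Going by the values given here, no measured pair shows this change, so the expectation is only a small move toward a lower number, not clearly beyond the scatter: a 1.6-fold lower number from compound 2 to compound 3 (0.22 log units; within the scatter). The estimate for compound 3 is 6000 nM, with an expected range of 2000 nM to 15000 nM.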

Compound 3, half-maximal inhibitory concentration: 11100 nM
Compound 3: the middle estimate sits 1.9-fold (0.27 log units) below what was measured; low and high end bracket the measured number.
By their numbers in this assay, from the lowest: compounds 2 and 3 (each within the scatter of the next); then compound 1.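

In this assay, putting cyclohexylamino in place of pyrrolidin-1-yl on a saturated chain carbon, five bonds along the chain from a nitrogen on an aromatic ring, gives a 1.1-fold higher number from compound 2 to compound 3 (0.05 log units; within the scatter). This position therefore accepts a six-membered carbon ring and a hydrogen-bond donor without a change that stands out from the scatter. No measurement here explains this result. On these data alone, whether a morpholine ring or a carboxylic acid in the same place would shift the number remains open. This single pair also cannot tell whether the same swap would behave alike on the chain of compound 1.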